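Three anilines around one core, and a fourth to predict

The source may hold more compounds than are shown below. What is called first, only, known or untested is meant among the compounds shown, and "the series" means these compounds.

Measured so far in a functional assay on A549 cells (Homo sapiens) for cytotoxicity, read by MTT assay, with a stated time of 48 h; on this read-out higher numbers stand for weaker inhibition and lower numbers for stronger inhibition:
compound 1 `Cc1ccc(S(=O)(=O)/N=C(/CCNC2=CC(=O)c3ccccc3C2=O)Nc2cccc(C(F)(F)F)c2)cc1` gives 78500 nM;
compound 2 `Cc1ccc(S(=O)(=O)/N=C(/CCNC2=CC(=O)c3ccccc3C2=O)Nc2ccc(F)c(F)c2)cc1` gives 16700 nM;
compound 3 `Cc1ccc(S(=O)(=O)/N=C(/CCNC2=CC(=O)c3ccccc3C2=O)Nc2ccc(Cl)cc2Cl)cc1` gives 32900 nM.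

Compound 3 sits second highest of the three, with a 2.0-fold higher number from compound 2 to compound 3 (0.29 log units; within the scatter) and a 2.4-fold lower number from compound 1 to compound 3 (0.38 log units; beyond the scatter). Compound 4 `Cc1ccc(S(=O)(=O)/N=C(/CCNC2=CC(=O)c3ccccc3C2=O)Nc2cc(F)c(F)c(F)c2)cc1` differs from compound 3 only by 3,4,5-trifluorophenyl in place of 2,4-dichlorophenyl on an amine nitrogen. Fluorinated phenyls already appear once: compound 2 carries 3,4-difluorophenyl, and the step of a 4.7-fold lower number from compound 1 to compound 2 (0.67 log units; beyond the scatter) was the largest seen. Since compound 4 resembles compound 2 most closely, its number in this assay is expected near that of compound 2, giving an estimated 1.6-fold lower number from compound 3 to compound 4 (0.22 log units; within the scatter) that stays within the scatter. Compound 4 is therefore estimated at 20000 nM, ranging from 7000 nM to 60000 nM.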

Compound 4, half-maximal inhibitory concentration: 10200 nM
Compound 4: middle estimate off by 2.0-fold (0.29 log units), on the high side; the range from low to high includes it.
By their numbers in this assay, from the lowest: compounds 4, 2 and 3 (each within the scatter of the next, the first and the last beyond it); then compound 1.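

In this assay, the 3,4,5-trifluorophenyl group on this amine nitrogen now separates clearly from 2,4-dichlorophenyl, with a 3.2-fold lower number from compound 3 to compound 4 (0.51 log units; beyond the scatter), and from 3-(trifluoromethyl)phenyl, with a 7.7-fold lower number from compound 1 to compound 4 (0.89 log units; beyond the scatter). The extra fluoro on the aromatic carbon cannot be told apart from hydrogen, since a 1.6-fold lower number from compound 2 to compound 4 (0.21 log units; within the scatter) stays within the scatter. No measurement shown here explains these differences.

All four rings carry only fluoro, chloro or trifluoromethyl groups. As far as these compounds go, how a ring bearing a methoxy group, an amine or a carboxylic acid would behave remains open.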